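Swapping amino(phenyl)methyl for methyl on a shared core

The compounds below may be only part of what the source reports. "The series", "measured", "known", "first", "only" and "open" are said of these compounds alone.

Compound 1 `N[C@H](C(=O)OCCCOC1(c2ccc(Cl)cc2)c2ccccc2C(=O)N1Cc1ccccc1)c1ccccc1` gives 43000 nM
Compound 2 `CC(C)[C@H](N)C(=O)OCC(C)(C)COC1(c2ccc(Cl)cc2)c2ccccc2C(=O)N1Cc1ccc(Cl)cc1` gives 40000 nM

Going by the values given here, in a functional assay on HCT-116 cells (Homo sapiens) for inhibition, read by fluorescence, with a stated time of 48 h (on this read-out higher numbers stand for weaker inhibition of growth and lower numbers for stronger inhibition of growth), compound 1 and compound 2 lie within the scatter of each other, so compound 1 stands level with the only other measured compound. Compound 3 `CC(=O)OCCCOC1(c2ccc(Cl)cc2)c2ccccc2C(=O)N1Cc1ccccc1` has not yet been measured. It keeps the core of compound 1 but carries methyl in place of amino(phenyl)methyl on a carbonyl carbon so that acetyl replaces (amino(phenyl)methyl)carbonyl. Among the compounds with values here, no measured pair shows this change alone, so its effect cannot be read directly. In this assay, within the data shown here, no step beyond the scatter is expected, and the only anchor is compound 1 at 43000 nM in this small set. The expected size of the change is a 1.4-fold lower number from compound 1 to compound 3 (0.16 log units; within the scatter) in this estimate. Compound 3 is estimated at 30000 nM with a likely range from 10000 nM to 80000 nM when it is tested.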

Compound 3, concentration for 50% growth inhibition: 80000 nM
Beside the measured number, compound 3's estimate is 2.7-fold (0.43 log units) below it, and the stated range covers the measured number.
By their numbers in this assay, from the lowest: compounds 2, 1 and 3 (each within the scatter of the next).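

Going by these compounds alone, this is the first direct reading of a change at this place, since compound 1 and compound 2 differ in more than one place. In this assay, putting methyl in place of amino(phenyl)methyl on a carbonyl carbon gives a 1.9-fold higher number from compound 1 to compound 3 (0.27 log units; within the scatter) and so stays within the usual scatter, even though the six-membered aromatic ring, the hydrogen-bond donor and acceptor and the defined stereocentre all leave at once. No supporting evidence bears on this result, so nothing can be said about what lies behind it.

Amine and phenyl ring leave together in this step, so a benzyl group, which keeps the ring without the amine, or an aminomethyl group, which keeps the amine without the ring, would be needed to separate them. Going by these compounds, whether a longer chain such as butyl on this carbonyl carbon would give a step beyond the scatter also remains open.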